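Ether series: 1-phenylethyl in place of 3-fluorobenzyl

A few compounds are considered here, and "the series" means these few. Any claim that something is new, unique, unknown or untested is made for them only; others in the source may bear on it.

Compound 1, `Cn1ncc2c(=O)n(-c3ccccc3)c(SC(C)(C)c3ccccc3)nc21`: 1900 nM
Compound 2, `Cn1ncc2c(=O)n(-c3ccccc3)c(SCc3cccc(F)c3)cc21`: 240 nM
Compound 3, `Cn1ncc2c(=O)n(-c3ccccc3)c(OCc3cccc(F)c3)nc21`: 775 nM

In an assay on isolated protein for inhibition of aldehyde dehydrogenase 1A1 (Homo sapiens) (a lower number here means a stronger inhibitor, a higher number a weaker inhibitor), compound 3 stands second highest of the three numbers: compound 1 lies above it and compound 2 below it, both gaps beyond the scatter. Compound 4, `CC(Oc1nc2c(cnn2C)c(=O)n1-c1ccccc1)c1ccccc1`, differs from compound 3 in one place: 1-phenylethyl in place of 3-fluorobenzyl on an oxygen on an aromatic ring. Among the compounds with values here, no pair of measured compounds isolates this change, so its direction is not anchored. Within the data shown here, the only measured compound with a branched group on the linking atom, compound 1, gives 1900 nM, the highest of the set. A modest step toward weaker inhibition is therefore expected, a 1.7-fold higher number from compound 3 to compound 4 (0.22 log units; within the scatter), with wide uncertainty. Compound 4 is expected to give 1300 nM, plausibly between 400 nM and 4000 nM.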

Compound 4, half-maximal inhibitory concentration: 2400 nM
For compound 4 the middle estimate is 1.8-fold (0.27 log units) below the measured one; the range from low to high includes it.
By their numbers in this assay, from the lowest: compound 2; then compound 3; then compounds 1 and 4 (each within the scatter of the next).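

Within the data shown here, replacing 3-fluorobenzyl with 1-phenylethyl on this oxygen weakens inhibition in this assay with a 3.1-fold higher number from compound 3 to compound 4 (0.49 log units; beyond the scatter) and gives the first single-change reading at this position. The position therefore responds to a change of group even though both groups hold 8 heavy atoms and one six-membered aromatic ring. Nothing available accounts for the step.

As far as these compounds go, it remains open whether the step follows the added branching or the lost fluorine. A plain benzyl group on the same oxygen would separate the two.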